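The source may hold more compounds than are shown below. What is called first, only, known or untested is meant among the compounds shown, and "the series" means these compounds.

Three compounds have so far been measured in an ADME assay on a cell-free system (plasma, Homo sapiens) for metabolic stability, read by LC-MS (a higher number here means that the compound lasts longer, a lower number that the compound disappears faster), and give these numbers:

compound 1 `NCc1ccc(C(=O)Nc2ccncc2F)cc1-c1cccc(C(=O)Oc2ccccc2)c1` gives 0.117 h
compound 2 `NCc1ccc(C(=O)Nc2ccncc2)cc1-c1cccc(C(=O)OCC2CCCCC2)c1` gives 1.65 h
compound 3 `NCc1ccc(C(=O)Nc2ccncc2F)cc1-c1cccc(C(=O)OCCO)c1` gives 1.35 h

Compound 2 with 1.65 h sits within the scatter of compound 3 with 1.35 h and well clear of compound 1 with 0.117 h on the short-lived side.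

Compound 4 `CCCOC(=O)c1cccc(-c2cc(C(=O)Nc3ccncc3)ccc2CN)c1` is still unmeasured. It differs from compound 2 in one place, by ethyl in place of cyclohexyl on a saturated chain carbon bound to an oxygen next to a carbonyl group and so cyclohexylmethoxycarbonyl turns into propoxycarbonyl.

Within the data shown here, only one measured step touches this place, and it is large: a 12-fold higher number from compound 1 to compound 3 (1.06 log units; beyond the scatter) with phenyl leaving. No phenyl takes part in the change to compound 4, where a saturated chain carbon holds that place on both sides, so the large step carries over poorly. Compound 3 with 1.35 h also has a saturated chain carbon there, and it stays within the scatter of compound 2 although both its group and its core differ.

No step beyond the scatter is therefore expected in this assay and the estimate leans only slightly lower, with a 1.3-fold lower number from compound 2 to compound 4 (0.10 log units; within the scatter) as the expected step. The estimated value for compound 4 is 1.3 h with an expected range from 0.6 h to 2.8 h in this measurement.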

Compound 4, half-life: 0.3 h
Compound 4: the middle estimate sits 4.3-fold (0.64 log units) above what was measured, and the stated range ends above it.
By their numbers in this assay, from the lowest: compound 1; then compound 4; then compounds 3 and 2 (each within the scatter of the next).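

In this assay this place proves sensitive even when no phenyl is involved: with a saturated chain carbon holding it on both sides, ethyl in place of cyclohexyl gives a 5.5-fold lower number from compound 2 to compound 4 (0.74 log units; beyond the scatter) on the shared core. The earlier step at this place, a 12-fold higher number from compound 1 to compound 3 (1.06 log units; beyond the scatter), had phenyl leaving and a different group entering, so it could not show that two saturated groups would also separate beyond the scatter. No outside measurement is available to explain this difference, so the step stands here as an observation only.

This single pair removes the ring and shortens the group together, so it cannot tell whether the ring itself or simply the number of carbons matters; an open-chain hexyl or a smaller ring such as cyclopropyl at the same place would pull those two apart. Also open, as far as these compounds go, is whether the same step would appear on the core of compound 1 and compound 3, and how an amine or a carboxylic acid at the end of the chain would behave in this assay.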